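The source may report more compounds than this note shows. Statements on the series, on what has been measured and on what is new or still open speak of the compounds shown alone.

Working notes on the series. In a functional assay on A-375 cells (Homo sapiens) for antiproliferative activity, read by CCK-8 assay, with a stated time of 72 h (on this read-out higher numbers stand for weaker inhibition and lower numbers for stronger inhibition), compound 1 `CCC(C)n1cnc2c(NCc3ccc(C(=O)Nc4ccccc4N)cc3)nc(Cl)nc21` gives 2880 nM, the middle of the measured numbers: compound 2 `Cc1ccc(Nc2nc(Cl)nc3c2ncn3Cc2ccc(C(=O)Nc3ccccc3N)cc2)cc1` gives 470 nM and compound 3 `Nc1ccccc1NC(=O)c1ccc(Cn2cnc3c(NCc4ccccc4)nc(Cl)nc32)cc1` gives 5830 nM. Compound 4 `CC(C)n1cnc2c(NCc3ccc(C(=O)Nc4ccccc4N)cc3)nc(Cl)nc21` is not yet measured. It differs from compound 1 by hydrogen in place of methyl on a saturated chain carbon, two bonds along the chain from an aromatic nitrogen, which reads as sec-butyl to isopropyl. Among the measured compounds shown here, the only measured step, a 12-fold higher number from compound 2 to compound 3 (1.09 log units; beyond the scatter), is benzyl in place of 4-methylphenyl on a nitrogen on an aromatic ring. For the measured compounds named here, it is large but sits elsewhere, and no measured step touches this chain. No step beyond the scatter is therefore expected, and no direction is favoured. The estimated change is a 1.0-fold higher number from compound 1 to compound 4 (0.02 log units; within the scatter). Compound 4 is expected at 3000 nM, within an estimated range of 1300 nM to 6500 nM.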

Compound 4, half-maximal inhibitory concentration: 2170 nM
For compound 4 the middle estimate is 1.4-fold (0.14 log units) above the measured one; the measured number falls inside the stated range.
By their numbers in this assay, from the lowest: compound 2; then compounds 4 and 1 (each within the scatter of the next); then compound 3.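

On this chain, sec-butyl to isopropyl gives a 1.3-fold lower number from compound 1 to compound 4 (0.12 log units; within the scatter) in this assay, so the two compounds cannot be told apart on this read-out. Within this pair, the methyl on a saturated chain carbon, two bonds along the chain from an aromatic nitrogen, can be replaced by hydrogen with no step beyond the scatter. No evidence on hand speaks to the reason for this result.

The compounds shown leave open whether a longer chain, a cyclopropyl group or a chain ending in an amine at this position would also stay within the scatter of compound 1.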